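Phenol methylation in a three-compound growth-inhibition series

This account rests on a few compounds, and the source may have more. Where it says the series, first, only, none or still open, it means among the compounds named here.

Measured compounds:
compound 1, `COc1ccc(/C=C/C2(C)C=CC(=O)O2)c(OC)c1OC`: in a functional assay on 786-0 cells (Homo sapiens) for inhibition, read by sulforhodamine B assay, with a stated time of 48 h (a lower number here means a stronger inhibitor of growth, a higher number a weaker inhibitor of growth), compound 1 gives 132000 nM
compound 2, `COc1c(O)ccc(/C=C/C2(C)C=CC(=O)O2)c1OC`: in this assay compound 2 gives 109000 nM
compound 3, `CC1(/C=C/c2ccccc2O)C=CC(=O)O1`: in this assay compound 3 gives 136000 nM

All three numbers sit close together; the value of compound 3 and the value of compound 1 are within the usual scatter of each other, as are the value of compound 3 and the value of compound 2, so no order among them can be claimed.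

One matched pair is available. Compound 1 arises from compound 2 by methyl in place of hydrogen on an oxygen on an aromatic ring, and this change gave a 1.2-fold higher number from compound 2 to compound 1 (0.08 log units; within the scatter).

The unmeasured compound 4, `COc1ccccc1/C=C/C1(C)C=CC(=O)O1`, arises from compound 3 by methyl in place of hydrogen on an oxygen on an aromatic ring. The place of this change, an oxygen on an aromatic ring whose other neighbour is an aromatic carbon, reads the same for both pairs, so this is the same change made on a different core. How the core of compound 3 differs from the core of compound 2 is not broken down here.

Because the same change gave a 1.2-fold higher number from compound 2 to compound 1 (0.08 log units; within the scatter), the step from compound 3 to compound 4 is expected to be small, a 1.0-fold higher number from compound 3 to compound 4 (0.01 log units; within the scatter), which rests on that single precedent alone. Compound 4 is therefore estimated at 140000 nM in this assay, with a likely range from 80000 nM to 250000 nM.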

Compound 4, concentration for total growth inhibition: 35400 nM
Estimate against measurement, compound 4: 4.0-fold (0.60 log units) above; the measured number lies below the stated range.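

In this assay, hydroxy to methoxy on the core of compound 3 gave a 3.8-fold lower number from compound 3 to compound 4 (0.58 log units; beyond the scatter), so the size of the step from this change did not carry over from one core to the other: the same change on two cores in this assay, a 1.2-fold higher number (0.08 log units; within the scatter) from compound 2 to compound 1 and a 3.8-fold lower number (0.58 log units; beyond the scatter) from compound 3 to compound 4, 4.7-fold (0.67 log units) apart, beyond the scatter of two such steps. In this series, then, a step read on one core is not a safe guide to the same change on another, as the step on the core of compound 2 stays within the scatter while the step on the core of compound 3 goes beyond it. Within the data shown here, with only two matched pairs, this shows that the outcome of the change depends on the core in these compounds, but it does not show which difference between the two cores is responsible, why the steps differ, or how the change would behave on any third core.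

The compounds shown leave open whether the step on the core of compound 3 is specific to methyl on that oxygen or would also appear with an ethyl group or a longer chain there. They also leave open what an amine or a fluorine in place of the hydroxy would do on either core.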